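A few compounds are considered here, and "the series" means these few. Any claim that something is new, unique, unknown or untested is made for them only; others in the source may bear on it.

Compound 1 `O=C(CCCc1ccc(F)cn1)N1CCc2c(Cl)c(O)c(O)c(Cl)c2C1`: 25%
Compound 2 `O=C(CCCc1ccc(C(F)(F)F)cn1)N1CCc2c(Cl)c(O)c(O)c(Cl)c2C1`: 19%
Compound 3 `COc1ccc(CCCC(=O)N2CCc3c(Cl)c(O)c(O)c(Cl)c3C2)nc1`: 31%

In a functional assay (Homo sapiens), tested at 10 uM (on this read-out higher numbers stand for a weaker effect at the one concentration tested and lower numbers for a stronger effect), compound 3 gives 31%. Set against the others, compound 3 is separated from compound 2 by a step that is beyond the scatter (a number 12 percentage points higher from compound 2 to compound 3 (beyond the scatter)), whereas the step toward it from compound 1 (a number 6 percentage points higher from compound 1 to compound 3 (within the scatter)) stays within it, so only the gap to compound 2 can be read as real.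

Compound 4 `CS(=O)(=O)c1ccc(CCCC(=O)N2CCc3c(Cl)c(O)c(O)c(Cl)c3C2)nc1` differs from compound 3 in one place: methylsulfonyl in place of methoxy on an aromatic carbon. Among the measured compounds shown here, no measured step swaps in a methylsulfonyl, so the only guide is the earlier exchanges at this same aromatic carbon, a number 6 percentage points lower from compound 1 to compound 2 (within the scatter), a number 6 percentage points higher from compound 1 to compound 3 (within the scatter) and a number 12 percentage points higher from compound 2 to compound 3 (beyond the scatter), all small. Compound 4 is therefore expected to land near compound 3, with a step of a number 1 percentage points lower from compound 3 to compound 4 (within the scatter) that need not exceed the scatter. Compound 4 is estimated at 30%, between 15% and 48%.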

Compound 4, a percentage reported as activity, at one concentration (the size of the read-out at that concentration, not a potency): 72%
The estimate for compound 4 lay 42 percentage points below the measured number; measured number above the stated range.
By their numbers in this assay, from the lowest: compounds 2, 1 and 3 (each within the scatter of the next, the first and the last beyond it); then compound 4.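

At this aromatic carbon, fluoro, trifluoromethyl and methoxy differ by modest steps at most, but methylsulfonyl brings a far weaker effect in this assay and gives a number 41 percentage points higher from compound 3 to compound 4 (beyond the scatter) and a number 53 percentage points higher from compound 2 to compound 4 (beyond the scatter) and also a number 47 percentage points higher from compound 1 to compound 4 (beyond the scatter) as large steps. The position is therefore not tolerant of every group, and one exchange here can outweigh all the earlier differences. No measurement shown accounts for this jump. Still open, as far as these compounds go, is how an amine, a carboxylic acid or a nitrile at this carbon would read, and whether methylthio would behave like methylsulfonyl or like methoxy.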